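The source may report more compounds than this note shows. Statements on the series, on what has been measured and on what is new or still open speak of the compounds shown alone.

Measured in a functional assay on HL-60 cells (Homo sapiens) for antiproliferative activity, read by MTT assay, with a stated time of 24 h; a lower number here means a stronger inhibitor, a higher number a weaker inhibitor:
- Compound 1 `CCCCc1oc2ccccc2c1C(=O)c1ccc(OCC(N)=O)cc1`: > 50000 nM
- Compound 2 `CCCCNC(=O)COc1ccc(C(=O)c2c(CCCC)oc3ccccc23)cc1`: > 50000 nM
- Compound 3 `CCCCc1oc2ccccc2c1C(=O)c1ccc(OCC(=O)Nc2cccc(OC)c2)cc1`: > 50000 nM

Each of these values is a limit and not a number, so the series sits together: the limit of > 50000 nM in this assay, at which 3 of the 3 values shown sit.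

Compound 4 `CCCCc1oc2ccccc2c1C(=O)c1ccc(OCCCC(=O)N2CCCCC2)cc1` follows from compound 3 through one change: 2-((piperidin-1-yl)carbonyl)ethyl in place of (3-methoxyphenyl)carbamoyl on a saturated chain carbon bound to an oxygen on an aromatic ring. In words, 2-((piperidin-1-yl)carbonyl)ethyl takes the place of (3-methoxyphenyl)carbamoyl on a saturated chain carbon bound to an oxygen on an aromatic ring.

Among the compounds with values here, the steps that bear on this are a step that the two limits leave unreadable from compound 1 to compound 2, a step that the two limits leave unreadable from compound 1 to compound 3 and a step that the two limits leave unreadable from compound 2 to compound 3. None has a readable size, and none gives a direction. No step beyond the scatter is therefore expected in this assay.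

The expected step is a number no higher from compound 3 to compound 4 (the limit leaves the size open).

For compound 4 the estimate is 50000 nM, with an expected range from 20000 nM to 100000 nM.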

Compound 4, half-maximal inhibitory concentration: 31900 nM
For compound 4 the middle estimate is 1.6-fold (0.20 log units) above the measured one, and the stated range covers the measured number.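

Of the four compounds, only compound 4 gives a number and not a limit in this assay: the limit of > 50000 nM in this assay, at which 3 of the 4 values shown sit.

With 2-((piperidin-1-yl)carbonyl)ethyl on the saturated chain carbon, the change gives an at least 1.5-fold lower number from compound 3 to compound 4 (0.19 log units; that floor lies within the scatter), an at least 1.5-fold lower number from compound 2 to compound 4 (0.19 log units; that floor lies within the scatter) and an at least 1.5-fold lower number from compound 1 to compound 4 (0.19 log units; that floor lies within the scatter). Within the data shown here, the steps among compound 1, compound 2 and compound 3 cannot be read, so these floors, all within the scatter, are the only readable steps, and none establishes a real gain.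

The compounds shown leave open whether the piperidine ring or the ethyl part of the entering group matters, and how a morpholine amide or a carboxylic acid there would read in this assay.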